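The source may hold more compounds than are shown below. What is called first, only, known or untested is meant among the compounds shown, and "the series" means these compounds.

Compound 1 `O=C1O/C(=C\Cn2cc(-c3cc(F)cc(F)c3)nn2)C(OCc2ccccc2)=C1OCc1ccccc1`, compound 2 `O=C1O[C@H]([C@@H](O)Cn2cc(-c3cc(F)cc(F)c3)nn2)C(OCc2ccccc2)=C1OCc1ccccc1` and compound 3 `O=C1O/C(=C\Cn2cc(-c3cccc(O)c3)nn2)C(OCc2ccccc2)=C1OCc1ccccc1` share one core and differ in a side group and in the short chain that carries it. In a functional assay on SW-620 cells (Homo sapiens) for antiproliferative activity, read by MTT assay, with a stated time of 72 h (a lower number here means a stronger inhibitor, a higher number a weaker inhibitor), compound 1 gives > 100000 nM, which is a limit of the assay rather than a number. Compound 2 gives > 100000 nM in this assay, again a limit. Compound 3 gives 69800 nM. Within the data shown here, the only measured step, an at least 1.4-fold lower number from compound 1 to compound 3 (0.15 log units; that floor lies within the scatter), is small. Compound 2 thus stands at the limit of > 100000 nM in this assay, at which 2 of the 3 values shown sit. Compound 4 `O=C1O[C@H]([C@@H](O)Cn2cc(C3CC3)nn2)C(OCc2ccccc2)=C1OCc1ccccc1` differs from compound 2 by cyclopropyl in place of 3,5-difluorophenyl on an aromatic carbon. Among the measured compounds shown here, no measured step swaps in a cyclopropyl, and the one change at this position stayed within the scatter, so the step of a number no higher from compound 2 to compound 4 (the limit leaves the size open) is expected to be small. Compound 4 is estimated at 100000 nM, between 30000 nM and 300000 nM.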

Compound 4, half-maximal inhibitory concentration: 54200 nM
Estimate against measurement, compound 4: 1.8-fold (0.27 log units) above, within the range that was stated.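

In this assay there is an at least 1.8-fold lower number from compound 2 to compound 4 (0.26 log units; that floor lies within the scatter) on swapping the 3,5-difluorophenyl for cyclopropyl, 3 heavy atoms in place of 8. So on this chain, a small non-aromatic ring at this position still gives a value that reads as a number, which the 3,5-difluorophenyl did not. From the compounds shown here alone, the true size of the step stays unknown because compound 2 stands at a limit: the limit of > 100000 nM in this assay, at which 2 of the 4 values shown sit.

Going by these compounds, whether an amine, a carboxylic acid or a longer carbon chain at this position would shift the number remains open.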